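A few compounds are considered here, and "the series" means these few. Any claim that something is new, unique, unknown or untested is made for them only; others in the source may bear on it.

Of the compounds shown here, three of one shared core have been measured for binding at a single concentration. Compound 1 `CC1=C(C(=O)OCC(C)C)C(c2ccoc2)NC(=O)N1` gives 16% in an assay on membranes from HeLa cells for displacement of a labelled ligand from adenosine receptor A3 (Homo sapiens), read by scintillation counting, with a stated time of 180 min, tested at 1 uM; a lower number here means less inhibition, a higher number more inhibition at the concentration tested (going by the name of the read-out). Compound 2 `CC1=C(C(=O)OCC(C)C)C(c2cccs2)NC(=O)N1` gives 11% in this assay, and compound 3 `CCSC(=O)C1=C(C)NC(=O)NC1c1ccoc1` gives 1% in this assay.

Two changes link these numbers. From compound 1 to compound 2 the change is thiophen-2-yl in place of furan-3-yl on a saturated ring carbon, and the step it made is a number 5 percentage points lower from compound 1 to compound 2 (within the scatter). Among the measured compounds shown here, from compound 1 to compound 3 the change is ethylsulfanyl in place of isobutoxy on a carbonyl carbon, and the step is a number 15 percentage points lower from compound 1 to compound 3 (beyond the scatter); this is the one step here that lies beyond the scatter, so compound 3 sits lower than compound 1. Compound 2 and compound 3 lie within the scatter of each other.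

Compound 4 `CCSC(=O)C1=C(C)NC(=O)NC1c1cccs1` has not yet been measured. It differs from compound 3 by thiophen-2-yl in place of furan-3-yl on a saturated ring carbon. For the measured compounds named here, this is the same kind of change as the one from compound 1 to compound 2, though the surroundings differ: in compound 1 the neighbouring ring atom bears a group of 7 heavy atoms, whereas in compound 3 it bears a (ethylsulfanyl)carbonyl group (5 heavy atoms). Because that earlier change gave a number 5 percentage points lower from compound 1 to compound 2 (within the scatter), the step expected from compound 3 to compound 4 is small, a number 1 percentage points lower from compound 3 to compound 4 (within the scatter), and since compound 3 already gives 1%, little room remains to go lower. Compound 4 is therefore estimated to give 0% in this assay, expected between -8% and 10%.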

Compound 4, a percentage reported as inhibition, at one concentration (the size of the read-out at that concentration, not a potency): 1%
Estimate against measurement, compound 4: 1 percentage points below, and the stated range covers the measured number.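

Replacing furan-3-yl with thiophen-2-yl while the ethylsulfanyl group stays in place gives no change at the digits printed from compound 3 to compound 4 (within the scatter) in this assay, and the change reads alike on the two cores: the same change on two cores in this assay, a number 5 percentage points lower (within the scatter) from compound 1 to compound 2 and no change at the digits printed (within the scatter) from compound 3 to compound 4, 5 percentage points apart, within the scatter of two such steps

Ethylsulfanyl in place of isobutoxy, with thiophen-2-yl on the ring, gives a number 10 percentage points lower from compound 2 to compound 4 (within the scatter), and this change also reads alike in the two settings: the same change on two cores in this assay, a number 15 percentage points lower (beyond the scatter) from compound 1 to compound 3 and a number 10 percentage points lower (within the scatter) from compound 2 to compound 4, 5 percentage points apart, within the scatter of two such steps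

This agreement does not prove that either change carries over unaltered, since all of these numbers are small, a single concentration gives no potency, and the ring change has left little room to show a difference between cores.

The compounds shown carry only furan-3-yl or thiophen-2-yl on the saturated ring carbon, and only isobutoxy or ethylsulfanyl on the carbonyl carbon, so it remains open how a phenyl ring at the first place, or an amine forming an amide at the second, would read in this assay. As far as these compounds go, a longer chain on the sulfur is equally open, as is whether any such group would move the number clearly beyond the scatter of these four compounds.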